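Extending the Chain on Sulfur: Compounds 1 to 4

The compounds below may be only part of what the source reports. "The series", "measured", "known", "first", "only" and "open" are said of these compounds alone.

Measured in a functional assay on the whole organism (strain NMRI) with Mus musculus as the target, with a stated time of 60 min, at a dose of 5 mg/kg by the intraperitoneal route; a higher number here means a stronger effect of the compound at the dose given, a lower number a weaker effect:
compound 1, `CSc1nnc(Cc2ccccc2Oc2ccccc2)[nH]1`, 120%
compound 2, `CCSc1nnc(Cc2ccccc2Oc2ccccc2)[nH]1`, 132%
compound 3, `CCSc1nnc(Cc2ccc(Cl)cc2Oc2ccccc2Cl)[nH]1`, 134%

Compound 2 differs from compound 1 by methyl in place of hydrogen on a saturated chain carbon bound to a sulfur, and this brought a step of a number 12 percentage points higher from compound 1 to compound 2 (beyond the scatter). Compound 3 carries a different core from compound 1; the difference between the two cores is not broken down here. In this assay compound 3 and compound 2 give values that lie within the scatter of each other, so nothing separates them.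

Compound 4, `CCCSc1nnc(Cc2ccc(Cl)cc2Oc2ccccc2Cl)[nH]1`, is not yet measured. It differs from compound 3 by methyl in place of hydrogen on a saturated chain carbon, two bonds along the chain from a sulfur. This is the same kind of change as that from compound 1 to compound 2, but not the same: there the added methyl sat on a saturated chain carbon bound to a sulfur, here it sits two bonds along the chain from a sulfur. Within the data shown here, the only guide is the modest step from compound 1 to compound 2, a number 12 percentage points higher from compound 1 to compound 2 (beyond the scatter). Resting on that step, compound 4 is expected to show a number 6 percentage points higher from compound 3 to compound 4 (within the scatter), an estimated value of 140%, somewhere between 115% and 165%.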

Compound 4, a percentage reported as activity, at one dose (the size of the read-out at that dose, not a potency): 118%
The estimate for compound 4 lay 22 percentage points above the measured number; measured number inside the range.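

In this assay, adding a methyl to the chain on sulfur did not carry over from one core to the other: the step to the propylsulfanyl chain was a number 16 percentage points lower from compound 3 to compound 4 (beyond the scatter), opposite in direction to the earlier step and clearly different from it: the same change on two cores in this assay, a number 12 percentage points higher (beyond the scatter) from compound 1 to compound 2 and a number 16 percentage points lower (beyond the scatter) from compound 3 to compound 4, 28 percentage points apart, beyond the scatter of two such steps

This shows that the earlier gain from the methyl to ethyl change cannot be taken as a guide to what a further methyl does on the core of compound 3. It does not show whether the core or the chain is behind the difference, for the two steps also differ in place, one being methyl to ethyl and the other ethyl to propyl, and each was read only once.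

The compounds shown leave open what a propylsulfanyl chain does on the core of compound 1, a pairing that would separate the effect of the core from that of chain length. They also leave open how a longer chain such as butyl, or a benzyl group on the sulfur, would behave on either core.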